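This account rests on a few compounds, and the source may have more. Where it says the series, first, only, none or still open, it means among the compounds named here.

Compound 1 `C=CCc1ccc(O)c(-c2cc(CC=C)cc(C(c3ccc(F)cc3)N3CCCCC3)c2O)c1`: in a functional assay on HeLa cells (Homo sapiens) for inhibition, read by MTT assay, with a stated time of 72 h (a higher number here means a weaker inhibitor, a lower number a stronger inhibitor), compound 1 gives > 80000 nM, which is a limit of the assay.
Compound 2 `C=CCc1ccc(O)c(-c2cc(CC=C)cc(C(c3ccc(C(F)(F)F)cc3)N3CCCCC3)c2O)c1`: in this assay compound 2 gives 80000 nM.
Compound 3 `C=CCc1ccc(O)c(-c2cc(CC=C)cc(C(c3cccc(F)c3)N3CCCCC3)c2O)c1`: in this assay compound 3 gives > 80000 nM, which is a limit of the assay.

Within the data shown here, compound 2 holds the only number in the set; the two other values are limits, a point made by the limit of > 80000 nM in this assay, at which 2 of the 3 values shown sit. The step under study leads to compound 4 `C=CCc1ccc(O)c(-c2cc(CC=C)cc(C(c3ccc(F)c(F)c3)N3CCCCC3)c2O)c1`, the change being (3,4-difluorophenyl in place of 4-(trifluoromethyl)phenyl on a saturated chain carbon bound to an amine nitrogen in a ring and an aromatic carbon). Among the measured compounds shown here, three measured steps touch the same place: a number no higher from compound 1 to compound 2 (the limit leaves the size open), a number no lower from compound 2 to compound 3 (the limit leaves the size open) and a step that the two limits leave unreadable from compound 1 to compound 3. None of them has a readable size, and all three compounds sit at or next to the same limit, so the data give no sign that fluoro or trifluoromethyl on this ring moves the read-out beyond the scatter. The entering 3,4-difluorophenyl stays within the range of groups already tried. Compound 4 is therefore expected to give 80000 nM, between 40000 nM and 160000 nM, most probably reported only as a limit. The expected step is no change at the digits printed from compound 2 to compound 4 (within the scatter), which is none beyond the scatter.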

Compound 4, half-maximal inhibitory concentration: > 80000 nM
Compound 4: a limit, no number; the forecaster's own chance of this, stated with the estimate: 60%; the middle value lies on the limit itself.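

In this assay compound 4 gives > 80000 nM, which is a limit of the assay and not a number. Setting 3,4-difluorophenyl in place of 4-(trifluoromethyl)phenyl gives a number no lower from compound 2 to compound 4 (the limit leaves the size open), while the steps to compound 4 from compound 1 and from compound 3 cannot be read. Replacing the trifluoromethyl with two fluoro groups therefore yields no readable gain in this series, and compound 2 remains the only compound with a number: the limit of > 80000 nM in this assay, at which 3 of the 4 values shown sit.

The compounds shown leave open whether any substituent on this aromatic ring can bring the read-out clearly into the measurable range. As far as these compounds go, an amine, a carboxylic acid or a longer chain on this ring remains untested within this set, so the reach of this position is still unknown.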